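Phenyl for Methyl: One Change Seen Twice

The source may report more compounds than this note shows. Statements on the series, on what has been measured and on what is new or still open speak of the compounds shown alone.

Going by the values given here, compound 1 `COc1ccc(C2C(C#N)=C(N)Oc3c2c(C)nn3-c2ccccc2)cc1` is one of three compounds measured in a functional assay on NCI-H2122 cells (Homo sapiens) for inhibition, read by microscopy, with a stated time of 10 days (on this read-out lower numbers stand for stronger inhibition and higher numbers for weaker inhibition), where compound 1 gives 4100 nM. Compound 2 `COc1ccc(C2C(C#N)=C(N)Oc3c2c(-c2ccccc2)nn3-c2ccccc2)cc1` differs from it in one place: phenyl in place of methyl on an aromatic carbon. In this assay compound 2 gives 3100 nM, so the step of a 1.3-fold lower number from compound 1 to compound 2 (0.12 log units; within the scatter) is too small to count as a real difference. Compound 3 `Cc1nn(C)c2c1C(c1ccc(C(C)C)cc1)C(C#N)=C(N)O2` rests on a core whose difference from the core of compound 1 is not broken down here; in this assay compound 3 gives 4000 nM, a number within the scatter of both compound 1 and compound 2.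

Compound 4 `CC(C)c1ccc(C2C(C#N)=C(N)Oc3c2c(-c2ccccc2)nn3C)cc1` has not yet been measured. It differs from compound 3 in one place: phenyl in place of methyl on an aromatic carbon. Among the compounds with values here, this is the same kind of change as the one from compound 1 to compound 2, but not the same: around the place, the ring atom two ring bonds away bears a methyl group (1 heavy atom) in compound 3, where in compound 1 it bears a phenyl group (6 heavy atoms). Within the data shown here, the only guide is the step seen once, a 1.3-fold lower number from compound 1 to compound 2 (0.12 log units; within the scatter), which lay within the scatter. Compound 4 is expected to give about 3200 nM in this assay, within a range of 1600 nM to 6400 nM. Among the measured compounds shown here, for compound 4 that estimate means a step of a 1.3-fold lower number from compound 3 to compound 4 (0.10 log units; within the scatter), which is expected because the single earlier instance a 1.3-fold lower number from compound 1 to compound 2 (0.12 log units; within the scatter) stayed within the scatter. For the measured compounds named here, only one compound bears phenyl in that place, so this rests on a single comparison.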

Compound 4, half-maximal inhibitory concentration: 5400 nM
Beside the measured number, compound 4's estimate is 1.7-fold (0.23 log units) below it; measured number inside the range.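

In this assay, the new step is a 1.4-fold higher number from compound 3 to compound 4 (0.13 log units; within the scatter), so on this second core, too, phenyl in place of methyl on this aromatic carbon gives no difference that stands clear of the normal spread of repeated measurements. Set side by side, the two instances of the change cannot be told apart: the same change on two cores in this assay, a 1.3-fold lower number (0.12 log units; within the scatter) from compound 1 to compound 2 and a 1.4-fold higher number (0.13 log units; within the scatter) from compound 3 to compound 4, 1.8-fold (0.25 log units) apart, within the scatter of two such steps. This shows that, in these two pairs, the change carries from one core to the other without any measurable shift, but it does not show that the change has no effect at all, since a small effect could hide inside the scatter, and two pairs say nothing firm about a third core.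

The compounds shown leave open whether a group of a different kind on this aromatic carbon, such as an amine, a carboxylic acid or a longer chain, would stand apart from methyl and phenyl in this assay. Also open, as far as these compounds go, is whether the step would stay this small on other cores, a question that only further matched pairs could settle.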